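A few compounds are considered here, and "the series" means these few. Any claim that something is new, unique, unknown or untested is made for them only; others in the source may bear on it.

Working notes on the series, read in a functional assay (muscle tissue) for inhibition, with Homo sapiens as the target; a higher number here means a weaker inhibitor, a lower number a stronger inhibitor. Compound 1 (`O=C(N[C@@H](CCC(=O)N1CCN(c2cccc(NC3=NCCN3)c2)CC1)C(=O)O)OCc1ccccc1`) gives 3 nM, and compound 2 (`O=C(N[C@@H](CCC(=O)N1CCN(c2cccc(NC3=NCCCN3)c2)CC1)C(=O)O)OCc1ccccc1`) gives 1.1 nM, the lower of the two numbers and so the stronger inhibitor of this pair. Among the compounds with values here, the only measured step, a 2.7-fold lower number from compound 1 to compound 2 (0.44 log units; beyond the scatter), puts a six-membered non-aromatic ring in place of a five-membered one, on a nitrogen on an aromatic ring.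

Compound 3 (`CCNC(=O)N[C@@H](CCC(=O)N1CCN(c2cccc(NC3=NCCCN3)c2)CC1)C(=O)O`) departs from compound 2 elsewhere: ethylamino in place of benzyloxy on a carbonyl carbon. In words, this is ethylamino in place of benzyloxy on a carbonyl carbon, so the six-membered aromatic ring leaves with the benzyloxy group. Within the data shown here, no measured pair varies this place, and the step to compound 2 at 1.1 nM serves only as a gauge of size, not as a guide to direction. The replacement here is larger than that ring change, so a step of greater size towards a higher number is the working expectation, held with wide uncertainty. The estimated change is a 7.3-fold higher number from compound 2 to compound 3 (0.86 log units; beyond the scatter). For compound 3 the expected value is 8 nM, with an estimated range of 1.5 nM to 45 nM.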

Compound 3, half-maximal inhibitory concentration: > 10 nM
Compound 3: only a limit was reported; the forecaster's own chance of this, stated with the estimate: 3%; at least 1.2-fold (0.09 log units) between middle value and limit.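

Compound 3 carries only a limit in this assay, not a true number: the limit of > 10 nM in this assay, at which 1 of the 3 values shown sits.

Replacing benzyloxy with ethylamino on the carbonyl carbon gives an at least 9.0-fold higher number from compound 2 to compound 3 (0.95 log units; beyond the scatter), which shows that this position, held constant in the earlier pair, is not indifferent to change in the series. Even as a minimum, this step is larger in size than the only earlier one, a 2.7-fold lower number from compound 1 to compound 2 (0.44 log units; beyond the scatter), so the change from benzyloxycarbonyl to ethylcarbamoyl counts for more here than the change of ring size on the aromatic nitrogen.

The compounds shown leave open how far the true step extends past its minimum, and whether it follows from the loss of the six-membered aromatic ring, the shorter group, or the nitrogen entering in place of the oxygen, since all of these change together in this one step. A benzylamino group on the same carbonyl carbon would keep the aromatic ring alongside the entering nitrogen, while an ethoxy group would keep the oxygen without the ring, so the two would begin to separate these contributions.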